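A few compounds are considered here, and "the series" means these few. Any claim that something is new, unique, unknown or untested is made for them only; others in the source may bear on it.

Measured compounds:
compound 1 `CCN1CCN(c2cc(C)c3cc(NC(=O)c4cccc(C)c4)ccc3n2)CC1`, 13700 nM
compound 2 `Cc1cc(N2CCN(C)CC2)nc2ccc(NC(=O)c3ccc(Cl)c(Cl)c3)cc12`, 6320 nM
compound 3 `Cc1cc(NCCN2CCCCC2)nc2ccc(NC(=O)c3ccc(Cl)c(Cl)c3)cc12`, 1800 nM

All three numbers come from a functional assay on SK-BR-3 cells (Homo sapiens) for antiproliferative activity, read by MTT assay, with a stated time of 72 h; on this read-out lower numbers stand for stronger inhibition and higher numbers for weaker inhibition. Compound 1 gives the highest number of the three: compound 2 sits at 6320 nM, and compound 3, at 1800 nM, is the furthest from it. Among the measured compounds shown here, the one step that can be read within the measured set, a 3.5-fold lower number from compound 2 to compound 3 (0.55 log units; beyond the scatter), concerns the group on the aromatic carbon of the shared core and leaves the benzamide part untouched.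

Compound 4 `CCN1CCN(c2cc(C)c3cc(NC(=O)c4ccccc4OC)ccc3n2)CC1` is the next compound. Relative to compound 1 it changes only the benzamide part: 2-methoxyphenyl in place of 3-methylphenyl on a carbonyl carbon. For the measured compounds named here, no measured pair varies this part of the molecule, so the single known step, from compound 2 to compound 3, does not bear on the change in hand. With nothing in the measured set pointing either way, no step beyond the scatter is expected for compound 4 in this assay, and the estimate stays near the number of compound 1, with a wide range on both sides to reflect the missing precedent.

Compound 4 is therefore expected at 12000 nM, within 4000 nM to 40000 nM. The step this implies, a 1.1-fold lower number from compound 1 to compound 4 (0.06 log units; within the scatter), is an expectation only.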

Compound 4, half-maximal inhibitory concentration: 15700 nM
Beside the measured number, compound 4's estimate is 1.3-fold (0.12 log units) below it, within the range that was stated.
By their numbers in this assay, from the lowest: compound 3; then compound 2; then compounds 1 and 4 (each within the scatter of the next).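

In this assay, among the compounds shown here, the benzamide part now has its only readable step, and a 1.1-fold higher number from compound 1 to compound 4 (0.06 log units; within the scatter) is within the scatter, so the numbers of these two compounds cannot be told apart. On the core of compound 1, this position therefore takes 2-methoxyphenyl in place of 3-methylphenyl on a carbonyl carbon without a measurable difference in this read-out, even though the entering group adds an oxygen and a hydrogen-bond acceptor that the leaving group lacks. No measurement of any property of these compounds bears on this result.

An amine or a carboxylic acid on the phenyl group, or a longer chain in place of the methoxy group, lies outside the compounds shown, so it remains open whether this position stays as insensitive to other groups. Also open, on these data alone, is whether (2-(piperidin-1-yl)ethyl)amino, the change behind a 3.5-fold lower number from compound 2 to compound 3 (0.55 log units; beyond the scatter), would give a step of similar size with 3-methylphenyl or 2-methoxyphenyl on the carbonyl carbon.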